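The compounds below may be only part of what the source reports. "The series", "measured", "known", "first", "only" and "open" are said of these compounds alone.

The measured compounds are:

compound 1 `O=c1c(SC(=S)N2CCCCC2)coc2ccccc12`, 9000 nM;
compound 2 `O=c1cc(CSC(=S)N2CCCCC2)oc2ccccc12`, a limit of > 25000 nM;
compound 3 `O=c1c(Cl)c(CSC(=S)N2CCCCC2)oc2ccccc12`, 9800 nM.

In a functional assay on HeLa cells (Homo sapiens) for antiproliferative activity, read by MTT assay, with a stated time of 72 h (on this read-out higher numbers stand for weaker inhibition and lower numbers for stronger inhibition), compound 1 gives 9000 nM. Compound 2 reaches only the limit of the assay, > 25000 nM, so no number is known for it; this is the limit described by the limit of > 25000 nM in this assay, at which 1 of the 3 values shown sits. Compound 3 gives 9800 nM. The values of compound 1 and compound 3 lie within the scatter of each other, so no order between them can be claimed. How the core of compound 1 differs from that of compound 2 is not broken down here.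

From compound 2 to compound 3 the change is chloro in place of hydrogen on an aromatic carbon, and it produced an at least 2.5-fold lower number from compound 2 to compound 3 (0.40 log units; beyond the scatter), though its true size is open because compound 2 sits at the limit (the limit of > 25000 nM in this assay, at which 1 of the 3 values shown sits).

Compound 4 `O=c1c(SC(=S)N2CCCCC2)coc2ccc(Cl)cc12` is not yet measured. It differs from compound 1 by chloro in place of hydrogen on an aromatic carbon. Going by the values given here, this is the same kind of change as the one from compound 2 to compound 3, but not the same: in compound 3 the chloro sits on a six-membered aromatic ring with 1 oxygen, ortho to a group of 1 heavy atom, ortho to a large group and two atoms from the ring oxygen, whereas in compound 4 it sits on a six-membered aromatic ring of carbon only.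

On this basis compound 4 is expected to show a 1.5-fold lower number from compound 1 to compound 4 (0.18 log units; within the scatter) in this assay, a step resting on an at least 2.5-fold lower number from compound 2 to compound 3 (0.40 log units; beyond the scatter) but tempered by the different surroundings of the change. Compound 4 is therefore estimated at 6000 nM, expected to fall between 2500 nM and 15000 nM.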

Compound 4, half-maximal inhibitory concentration: 8300 nM
Beside the measured number, compound 4's estimate is 1.4-fold (0.14 log units) below it; low and high end bracket the measured number.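

In this assay, chloro in place of hydrogen on an aromatic carbon gave a 1.1-fold lower number from compound 1 to compound 4 (0.04 log units; within the scatter), so on the core of compound 1 this change, made on the six-membered aromatic ring of carbon only, produced no shift that can be told from the scatter. Set beside the earlier step, the result reads as follows: the same change on two cores in this assay, an at least 2.5-fold lower number (0.40 log units; beyond the scatter) from compound 2 to compound 3 and a 1.1-fold lower number (0.04 log units; within the scatter) from compound 1 to compound 4; the limit leaves it open whether they differ The step beyond the scatter on one core therefore did not reappear beyond the scatter on the other, but this does not show that the two steps differ in size, nor does it show whether the core or the place of the chloro decides the outcome.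

The compounds shown leave open whether fluoro, bromo, methoxy or a nitrile in place of this chloro would move the number on the core of compound 1 beyond the scatter. They also leave open whether an amine, a carboxylic acid or a longer chain at that same aromatic carbon would do so, and how the chloro step would compare across the two cores with a measured number at both ends.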